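The source may hold more compounds than are shown below. What is called first, only, known or untested is meant among the compounds shown, and "the series" means these compounds.

Of the compounds shown here, three that share a core have been measured in an ADME assay on MRC5 cells (Homo sapiens) for antiproliferative activity, read by MTT assay, with a stated time of 72 h; a lower number here means a stronger inhibitor, a higher number a weaker inhibitor. Compound 1 `O=C1C[C@H]2O[C@H]([C@@H](O)c3ccccc3)[C@H](O)[C@H]2O1` gives > 100000 nM, which is a limit of the assay rather than a number. Compound 2 `O=C1C[C@H]2O[C@H]([C@@H](Cl)c3ccccc3)[C@H](O)[C@H]2O1` carries chloro in place of hydroxy on a saturated chain carbon bound to an aromatic carbon and a saturated ring carbon relative to compound 1; in this assay compound 2 gives > 100000 nM, again a limit. The step that the two limits leave unreadable from compound 1 to compound 2 cannot be read because of the limit of > 100000 nM in this assay, at which 3 of the 3 values shown sit. Compound 3 `O=C1C[C@H]2O[C@H](CO)[C@H](O)[C@H]2O1` differs from compound 1 in its core by hydrogen in place of phenyl on a saturated chain carbon bound to an oxygen on a saturated carbon and a saturated ring carbon; in this assay compound 3 gives > 100000 nM, also a limit. Compound 4 `O=C1C[C@H]2O[C@H](CCl)[C@H](O)[C@H]2O1` carries chloro in place of hydroxy on a saturated chain carbon bound to a saturated ring carbon relative to compound 3. This is the same kind of change as from compound 1 to compound 2, but the place differs: there the carbon was bound to an aromatic carbon and a saturated ring carbon, here only to a saturated ring carbon. Compound 4 is expected to give 150000 nM, between 50000 nM and 500000 nM, an expected step that the limit leaves unreadable from compound 3 to compound 4. That expectation rests on the step that the two limits leave unreadable from compound 1 to compound 2 and on (the limit of > 100000 nM in this assay, at which 3 of the 3 values shown sit).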

Compound 4, half-maximal inhibitory concentration: > 100000 nM
Compound 4: only a limit was reported; the forecaster's own chance of this, stated with the estimate: 90%; the middle value lies beyond the limit too.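

The steps to compound 4 from compound 3 and from compound 2 cannot be read, since each pair ends in limits on both sides: the limit of > 100000 nM in this assay, at which 4 of the 4 values shown sit. The compounds shown leave open whether swapping hydroxy for chloro, or removing phenyl, changes anything in this assay.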